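Fluoro for Methyl on a Methoxy-Bearing Core

A few compounds are considered here, and "the series" means these few. Any claim that something is new, unique, unknown or untested is made for them only; others in the source may bear on it.

Of the compounds shown here, three that share a core have been measured in a functional assay on HCT-116 cells (Homo sapiens) for antiproliferative activity, read by MTT assay, with a stated time of 48 h; a lower number here means a stronger inhibitor, a higher number a weaker inhibitor. Compound 2 `Cc1cnc(Nc2ccc(S(N)(=O)=O)cc2)nc1Nc1nc2ccc(Cl)cc2s1` gives 2520 nM. Compound 1 `NS(=O)(=O)c1ccc(Nc2ncc(F)c(Nc3nc4ccc(Cl)cc4s3)n2)cc1` differs from compound 2 by fluoro in place of methyl on an aromatic carbon, and compound 1 gives 8620 nM; the step is a 3.4-fold higher number from compound 2 to compound 1 (0.53 log units; beyond the scatter). Compound 3 `COc1ccc2nc(Nc3nc(Nc4ccc(S(N)(=O)=O)cc4)ncc3C)sc2c1` differs from compound 2 in its core by methoxy in place of chloro on an aromatic carbon, and compound 3 gives 7860 nM; that step is a 3.1-fold higher number from compound 2 to compound 3 (0.49 log units; beyond the scatter).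

Compound 4 `COc1ccc2nc(Nc3nc(Nc4ccc(S(N)(=O)=O)cc4)ncc3F)sc2c1` has not yet been measured. It differs from compound 3 by fluoro in place of methyl on an aromatic carbon, the same change that separates compound 1 from compound 2, at a place described in the same words. Within the data shown here, whether this change behaves alike on the core of compound 3 is not known from these three compounds; the one earlier step is the only guide, and the two cores differ only by a methoxy in place of a chloro. On that basis a step of a 3.2-fold higher number from compound 3 to compound 4 (0.50 log units; beyond the scatter) is expected in this assay, close to the step already seen. For compound 4 the expected value is 25000 nM, with a likely range from 10000 nM to 60000 nM.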

Compound 4, half-maximal inhibitory concentration: 11500 nM
For compound 4 the middle estimate is 2.2-fold (0.34 log units) above the measured one; measured number inside the range.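

In this assay, fluoro in place of methyl on the core of compound 3 gives a 1.5-fold higher number from compound 3 to compound 4 (0.17 log units; within the scatter), and this step cannot be told apart from the same change on the core of compound 2: the same change on two cores in this assay, a 3.4-fold higher number (0.53 log units; beyond the scatter) from compound 2 to compound 1 and a 1.5-fold higher number (0.17 log units; within the scatter) from compound 3 to compound 4, 2.3-fold (0.37 log units) apart, within the scatter of two such steps. Methoxy in place of chloro, read on the fluoro-bearing pair, gives a 1.3-fold higher number from compound 1 to compound 4 (0.13 log units; within the scatter), and this step also agrees with its earlier counterpart: the same change on two cores in this assay, a 3.1-fold higher number (0.49 log units; beyond the scatter) from compound 2 to compound 3 and a 1.3-fold higher number (0.13 log units; within the scatter) from compound 1 to compound 4, 2.3-fold (0.37 log units) apart, within the scatter of two such steps. Among these compounds, the two changes are therefore compatible with carrying over between these cores, but each rests on only two steps, one of them within the scatter, so this does not show that either change has a fixed size or that it would carry over to any other core.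

The compounds shown carry only methyl or fluoro on the six-membered aromatic ring with 2 nitrogen, and only chloro or methoxy at the other changed place. As far as these compounds go, how a nitrile or an amine would behave in place of the fluoro, on either core, remains open.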